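The compounds below may be only part of what the source reports. "The series", "measured", "known", "first", "only" and "open" are said of these compounds alone.

The series shares one core, carried on a butyl chain to an arylpiperazine. Compound 1 `Cn1c(=O)cnn(CCCCN2CCN(c3ccccc3)CC2)c1=O` bears an unsubstituted phenyl on the ring amine nitrogen, and in an assay for displacement of a labelled ligand from Adrenergic receptor alpha-1 (Homo sapiens) (on this read-out lower numbers stand for stronger inhibition and higher numbers for weaker inhibition), compound 1 gives 64 nM. Compound 2 `Cn1c(=O)cnn(CCCCN2CCN(c3c(Br)cccc3C#N)CC2)c1=O` carries 2-bromo-6-cyanophenyl in that position, and in this assay compound 2 gives 450 nM. Going by the values given here, of the two numbers known so far, compound 2 has the higher one, and the single step of a 7.0-fold higher number from compound 1 to compound 2 (0.85 log units; beyond the scatter) lies beyond the scatter.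

Compound 3 `Cn1c(=O)cnn(CCCCN2CCN(c3ccccc3F)CC2)c1=O` differs from compound 2 by 2-fluorophenyl in place of 2-bromo-6-cyanophenyl on an amine nitrogen in a ring. Among the compounds with values here, no measured step touches 2-fluorophenyl directly, so only the step from compound 1 to compound 2 bears on the question, and it shows that moving from plain phenyl to the doubly substituted ring raised the number. Compound 3 sits structurally nearer to compound 1 than to compound 2, so compound 3 is expected to return most of the way toward the number of compound 1, a step of a 5.6-fold lower number from compound 2 to compound 3 (0.75 log units; beyond the scatter) downward in this assay. Compound 3 is therefore estimated at 80 nM, with a range from 25 nM to 250 nM.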

Compound 3, inhibition constant: 9.73 nM
Compound 3: the middle estimate sits 8.2-fold (0.91 log units) above what was measured; measured number outside the range, below it.
By their numbers in this assay, from the lowest: compound 3; then compound 1; then compound 2.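

In this assay, the aryl group on the amine nitrogen in the ring proves able to move the number in either direction: fluoro in place of hydrogen on an aromatic carbon gives a 6.6-fold lower number from compound 1 to compound 3 (0.82 log units; beyond the scatter), whereas the 2-bromo-6-cyanophenyl group had given a 7.0-fold higher number from compound 1 to compound 2 (0.85 log units; beyond the scatter). A substituent on this phenyl ring therefore does not by itself raise the number, and the exchange of 2-bromo-6-cyanophenyl for 2-fluorophenyl spans the widest gap in the set, a 46-fold lower number from compound 2 to compound 3 (1.67 log units; beyond the scatter), leaving compound 3 with the lowest number of the three and beyond the scatter from both others. Nothing at hand explains why the fluoro group lowers the number or why the doubly substituted ring raises it.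

The compounds shown do not separate the bromo group from the nitrile, so 2-bromophenyl and 2-cyanophenyl would each be needed to tell which of them accounts for the rise. On these data alone, it also stays open whether the gain seen with fluoro extends to 2-chlorophenyl or 2-methoxyphenyl, or holds with a propyl chain in place of the butyl chain.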